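The compounds below may be only part of what the source reports. "The series", "measured", "known", "first", "only" and "open" are said of these compounds alone.

Compound 1 `O=C1NC(c2ccccc2)CN1S(=O)(=O)c1ccc2c(c1)CCCN2` carries a free hydrogen on the ring nitrogen of its shared core. In a functional assay on cells (KATO III cell, Homo sapiens) for antiproliferative activity, read by MTT assay (on this read-out higher numbers stand for weaker inhibition and lower numbers for stronger inhibition), compound 1 gives > 20000 nM, which is a limit of the assay and not a number, so compound 1 stands only as a weak inhibitor among the values shown (the limit of > 20000 nM in this assay, at which 1 of the 3 values shown sits). Compound 2 `COC(=O)N1CCCc2cc(S(=O)(=O)N3CC(c4ccccc4)NC3=O)ccc21` puts a methoxycarbonyl on that nitrogen and gives 16500 nM in this assay; the step of an at least 1.2-fold lower number from compound 1 to compound 2 (0.08 log units; that floor lies within the scatter). Compound 3 `NC(=O)N1CCCc2cc(S(=O)(=O)N3CC(c4ccccc4)NC3=O)ccc21`, with a carbamoyl there, gives 3590 nM in this assay. That step is an at least 5.5-fold lower number from compound 1 to compound 3 (0.74 log units; beyond the scatter), and from the ester to the primary urea the step is a 4.6-fold lower number from compound 2 to compound 3 (0.66 log units; beyond the scatter).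

Compound 4 `O=C(CCl)NC(=O)N1CCCc2cc(S(=O)(=O)N3CC(c4ccccc4)NC3=O)ccc21` has not yet been measured. Relative to compound 1 the change is ((chloromethyl)carbonyl)carbamoyl in place of hydrogen on a nitrogen on an aromatic ring in a ring. Among the measured compounds shown here, the step that bears most on it is the one from compound 1 to compound 3, since the entering group of compound 4 also contains a carbamoyl, and that step was at least modest; the ester of compound 2 showed that not every acyl group on this nitrogen lowers the number beyond the scatter. A lowering of about the same size as for compound 3 is therefore expected, that is, a step of an at least 5.7-fold lower number from compound 1 to compound 4 (0.75 log units; beyond the scatter) is expected. Compound 4 is estimated at 3500 nM, with a range from 900 nM to 14000 nM.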

Compound 4, half-maximal inhibitory concentration: 2540 nM
Beside the measured number, compound 4's estimate is 1.4-fold (0.14 log units) above it, and the stated range covers the measured number.
By their numbers in this assay, from the lowest: compounds 4 and 3 (each within the scatter of the next); then compound 2. At a limit, above all of these: compound 1.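

A (chloromethyl)carbonyl on the amide-type nitrogen of the primary urea gives no separable difference in this assay: the step is a 1.4-fold lower number from compound 3 to compound 4 (0.15 log units; within the scatter), so the two ureas stand level and this position accepts the full ((chloromethyl)carbonyl)carbamoyl group without a loss against the plain carbamoyl. Measured against the ester, the step is a 6.5-fold lower number from compound 2 to compound 4 (0.81 log units; beyond the scatter), so a second group built on a carbamoyl now stands apart from the methoxycarbonyl, and the lower number is no longer tied to the primary urea alone. Read from the free hydrogen, an at least 7.8-fold lower number from compound 1 to compound 4 (0.89 log units; beyond the scatter) is only a floor, since compound 1 holds a limit of the assay and not a number: the limit of > 20000 nM in this assay, at which 1 of the 4 values shown sits.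

The compounds shown leave open whether the chlorine itself counts, a question that an acetyl group in place of the (chloromethyl)carbonyl would address. They also leave open how far this nitrogen carries other groups, such as a longer chain on the urea or a simple alkyl amine on the carbonyl carbon.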